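The source may report more compounds than this note shows. Statements on the series, on what has been measured and on what is new or still open speak of the compounds shown alone.

Compound 2 `Cc1ccccc1-n1nc(C)c2c1NC(=O)[C@H](C)S[C@@H]2c1ccc(-c2cc3ccccc3o2)cc1` was tested in an assay on isolated protein for agonist activity at Bile acid receptor (Homo sapiens), read by AlphaScreen, with a stated time of 30 min (on this read-out lower numbers stand for an effect already at smaller amounts and higher numbers for an effect only at larger amounts of compound), and gave 1500 nM. That is the lowest of the two values available in this assay; the other, from compound 1 `Cc1ccc(-n2nc(C)c3c2NC(=O)[C@H](C)S[C@@H]3c2ccc(Oc3ccccc3)cc2)cc1`, which in this assay gave 3400 nM, lies higher by a margin beyond the scatter, so compound 2 is the more potent of the pair. The next compound, compound 3 `Cc1ccccc1-n1nc(C)c2c1NC(=O)[C@H](C)S[C@@H]2c1ccc(-c2ccc(C(=O)O)cc2)cc1`, differs from compound 2 in one place: 4-carboxyphenyl in place of 1-benzofuran-2-yl on an aromatic carbon. Among the compounds with values here, no measured pair in this set shows this kind of change, so its effect can only be expected, not read off. On the evidence of the two measured compounds, the step in this assay is expected to be a moderate move toward lower values, described by a 2.5-fold lower number from compound 2 to compound 3 (0.40 log units; beyond the scatter). Compound 3 is accordingly estimated at 600 nM in this assay, with a range from 120 nM to 3000 nM.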

Compound 3, half-maximal effective concentration: "not active" (no number reported)
For compound 3 the study gives words and no number, so the estimate cannot be set against anything.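

Within the data shown here, compound 3 was reported only in words, as not active, so no step from compound 2 to compound 3 can be read. Nothing available bears on the reason for this result. The compounds shown leave open how far 4-carboxyphenyl in place of 1-benzofuran-2-yl shifts the value on this core.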